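Swapping the Drawn Configuration at One Chain Stereocentre

The source may report more compounds than this note shows. Statements on the series, on what has been measured and on what is new or still open speak of the compounds shown alone.

Compound 1 `C[C@@H](/N=C(\S)Nc1nc2ccccc2s1)c1cccc2ccccc12`: 18900 nM
Compound 2 `Cc1cc(C)nc(N/C(S)=N/[C@H](C)c2cccc3ccccc23)c1`: > 100000 nM, a limit of the assay, not a number
Compound 3 `COc1cc2ncnc(Nc3cc(Br)c(O)c(Br)c3)c2cc1OC`: 6800 nM

In a functional assay on RBL-2H3 cells (Rattus norvegicus) for inhibition (on this read-out higher numbers stand for weaker inhibition and lower numbers for stronger inhibition), compound 1 gives 18900 nM, the highest of the two numbers shown. Its nearest neighbour is compound 3, whose lower number lies beyond the usual scatter. Compound 2 reaches only (the limit of > 100000 nM in this assay, at which 1 of the 3 values shown sits). Compound 4 `C[C@H](/N=C(\S)Nc1nc2ccccc2s1)c1cccc2ccccc12` is the next step from compound 1, and the change is the two compounds have the same atoms and bonds and differ only in configuration as drawn: 1 of 2 stereo elements differ; a stereocentre at a saturated chain carbon is drawn R in compound 1 and S in compound 4. No step of this kind between measured compounds is shown, so no direction can be read from the data; the expected step from compound 1 to compound 4 is a 1.1-fold lower number from compound 1 to compound 4 (0.02 log units; within the scatter), wide enough to allow movement either way. Compound 4 is therefore estimated at 18000 nM, with a range from 4000 nM to 80000 nM.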

Compound 4, half-maximal inhibitory concentration: > 100000 nM
Compound 4: only a limit was reported (the forecaster's own chance of this, stated with the estimate: 15%); middle value at least 5.5-fold (0.74 log units) from the limit.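

In this assay the stereocentre at the saturated chain carbon proves not to be neutral, and inverting it as drawn gives an at least 5.2-fold higher number from compound 1 to compound 4 (0.72 log units; beyond the scatter). Compound 4 gives > 100000 nM, which is a limit of the assay and not a number. None of the earlier compounds offered such a step, and this one isolates a single feature: the fact that compounds 1 and 4 differ only in the configuration as drawn

Going by these compounds, how far compound 4 lies past that limit stays unknown, so the full size of the step cannot be told. On these data alone, whether a longer chain or a carboxylic acid at this stereocentre would keep the inhibition seen with compound 1 also stays open.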